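Methylindolyl acyl urea replaces cyclopropylphenyl: lipophilicity expected unchanged

The source may report more compounds than this note shows. Statements on the series, on what has been measured and on what is new or still open speak of the compounds shown alone.

The measured compounds:
compound 1 `CN1CCN(CCCS(=O)(=O)c2ccc3nc(NC(=O)NC(=O)c4cc(-n5cccn5)ccc4Cl)sc3c2)CC1` with 2
compound 2 `CN1CCN(CCCS(=O)(=O)c2ccc3nc(NC(=O)NC(=O)c4cc(-n5cccc5)ccc4Cl)sc3c2)CC1` with 2.6
compound 3 `CN1CCN(CCCS(=O)(=O)c2ccc3nc(NC(=O)NC(=O)c4cc(C5CC5)ccc4Cl)sc3c2)CC1` with 2.9

In a physicochemical assay for lipophilicity (a lower number here means a more polar compound, a higher number a more lipophilic compound), compound 3 gives the highest of the three numbers; compound 2 sits a number 0.30 log units higher from compound 2 to compound 3 (within the scatter), and compound 1 sits a number 0.90 log units higher from compound 1 to compound 3 (beyond the scatter). Compound 4 `CN1CCN(CCCS(=O)(=O)c2ccc3nc(NC(=O)NC(=O)c4cc5c(ccn5C)cc4Cl)sc3c2)CC1` differs from compound 3 in one place: 5-chloro-1-methyl-1H-indol-6-yl in place of 2-chloro-5-cyclopropylphenyl on a carbonyl carbon. Among the compounds with values here, the steps that bear on it are those that remove the cyclopropyl group, a number 0.90 log units higher from compound 1 to compound 3 (beyond the scatter) and a number 0.30 log units higher from compound 2 to compound 3 (within the scatter); the entering group, like the pyrrolyl group of compound 2, carries a five-membered aromatic ring with one hetero atom, and that exchange stayed within the scatter. The expected step of a number 0.10 log units higher from compound 3 to compound 4 (within the scatter) is therefore small. Compound 4 is estimated at 3, with a range from 2.5 to 3.5.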

Compound 4, distribution coefficient: 2.8
Compound 4: the middle estimate sits 0.20 log units above what was measured; the measured number falls inside the stated range.
By their numbers in this assay, from the lowest: compound 1; then compounds 2, 4 and 3 (each within the scatter of the next).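

In this assay, 5-chloro-1-methyl-1H-indol-6-yl on a carbonyl carbon gives a number 0.10 log units lower from compound 3 to compound 4 (within the scatter) and a number 0.20 log units higher from compound 2 to compound 4 (within the scatter) so compound 4 cannot be told apart from either neighbour. Within the data shown here, the pyrazolyl-bearing compound stays apart, with a number 0.80 log units higher from compound 1 to compound 4 (beyond the scatter) as the only new step that clears the scatter. Nothing available explains these steps. Still open, from the compounds shown here alone, is how this assay would respond to a carboxylic acid or an amine on this group, or to a longer chain in place of its methyl.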